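The compounds below may be only part of what the source reports. "The series", "measured", "known", "first", "only" and "open" are said of these compounds alone.

Measured so far:
compound 1 `Cc1ccc2[nH]c(=O)c(CN(Cc3ccc(OCC(=O)O)cc3)Cc3ccc(C(C)(C)C)cc3)cc2c1`: > 10000 nM
compound 2 `CCc1ccc2[nH]c(=O)c(CN(Cc3ccc(C(C)(C)C)cc3)[C@H](CO)c3ccccc3)cc2c1`: > 10000 nM
compound 3 `CCc1ccc2[nH]c(=O)c(CN(Cc3ccc(C(C)(C)C)cc3)C(C)c3ccc(F)cc3)cc2c1`: 2800 nM

In a toxicity assay on MDCK cells (Canis lupus familiaris) for cytotoxicity, read by crystal violet staining, with a stated time of 48 h (a lower number here means that less compound is tolerated, a higher number that more compound is tolerated), compound 1 stands at a limit rather than a number, namely > 10000 nM. Compound 2 also sits at a limit, > 10000 nM. Compound 3 alone gives a number, 2800 nM. Two of the three values shown thus rest at the limit of > 10000 nM in this assay, at which 2 of the 3 values shown sit, so the position of compound 1 is known only as a limit.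

Within the data shown here, the one measured step between compounds differing in a single place is an at least 3.5-fold lower number from compound 2 to compound 3 (0.55 log units; beyond the scatter). Compound 4 `COc1ccc(C(C)N(Cc2ccc(C(C)(C)C)cc2)Cc2cc3cc(C)ccc3[nH]c2=O)cc1` arises from compound 1 by a change of the same kind, on the same amine nitrogen: 1-(4-methoxyphenyl)ethyl in place of 4-(carboxymethoxy)benzyl on an amine nitrogen. Among the measured compounds shown here, the measured step from compound 2 to compound 3 is the only guide, and it points to a lower number when such a group enters. A step of similar direction is therefore expected for compound 4, roughly an at least 2.5-fold lower number from compound 1 to compound 4 (0.39 log units; beyond the scatter). Compound 4 is estimated at 4000 nM, with a range from 1500 nM to 10000 nM.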

Compound 4, half-maximal cytotoxic concentration: > 5000 nM
Compound 4: a limit, no number; the forecaster's own chance of this, stated with the estimate: 35%; at least 1.2-fold (0.09 log units) between middle value and limit.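

Compound 1 and compound 4 both rest at limits rather than numbers, so the step between them cannot be read. The compounds shown leave open whether 1-(4-methoxyphenyl)ethyl in place of 4-(carboxymethoxy)benzyl on the amine nitrogen changes how much compound is tolerated, and in which direction.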